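The source may report more compounds than this note shows. Statements on the series, on what has been measured and on what is new or still open speak of the compounds shown alone.

Three compounds share one core and differ only in the amine attached to the sulfonyl sulfur. Compound 1 `CC(C)c1cccc(C(C)C)c1NC(=O)NS(=O)(=O)N1CCCC1` carries a pyrrolidin-1-yl group there and in an assay on liver for inhibition of sterol O-acyltransferase 1 (Rattus norvegicus), using microsomes (a lower number here means a stronger inhibitor, a higher number a weaker inhibitor), compound 1 gives 15000 nM. Compound 2 `CCCCN(C)S(=O)(=O)NC(=O)Nc1c(C(C)C)cccc1C(C)C` has a butyl(methyl)amino group in its place and gives 2300 nM; that change is a 6.5-fold lower number from compound 1 to compound 2 (0.81 log units; beyond the scatter). Compound 3 `CC(C)c1cccc(C(C)C)c1NC(=O)NS(=O)(=O)N(C(C)C)C(C)(C)C` bears an isopropyl(tert-butyl)amino group and gives 140 nM, the lowest number of the three and beyond the scatter from both others; the step from the ring compound is a 110-fold lower number from compound 1 to compound 3 (2.03 log units; beyond the scatter) and from the open-chain compound is a 16-fold lower number from compound 2 to compound 3 (1.22 log units; beyond the scatter).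

Compound 4 `CC(C)c1cccc(C(C)C)c1NC(=O)NS(=O)(=O)N(Cc1ccccc1)C(C)C` differs from compound 3 by benzyl in place of tert-butyl on a sulfonamide nitrogen. For the measured compounds named here, no measured step covers a benzyl group, so the expectation rests on the two steps into compound 3: both were large and both ended with an isopropyl(tert-butyl)amino group on that nitrogen, and compound 4 keeps the isopropyl part while the tert-butyl part is exchanged. Some of the advantage of compound 3 is therefore expected to be lost, but less than the whole step back to compound 2. The expected step in this assay is a 2.9-fold higher number from compound 3 to compound 4 (0.46 log units; beyond the scatter). Compound 4 is estimated at 400 nM, within a range of 120 nM to 1500 nM.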

Compound 4, half-maximal inhibitory concentration: 400 nM
For compound 4 middle estimate and measured number coincide at the digits printed; the measured number falls inside the stated range.
By their numbers in this assay, from the lowest: compound 3; then compound 4; then compound 2; then compound 1.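

In this assay, the step to the benzyl group is a 2.9-fold higher number from compound 3 to compound 4 (0.46 log units; beyond the scatter) and counts as modest, unlike the large steps that led to compound 3 from the other two compounds. For the compounds shown here, the earlier compounds carried only saturated groups on this sulfonamide nitrogen, so this result is the first to show that a six-membered aromatic ring can stand in place of tert-butyl at only a modest cost: compound 4 gives 400 nM and still has a lower number than compound 2, which gives 2300 nM and differs from it in both groups on that nitrogen. Nothing available explains why benzyl gives a higher number than tert-butyl at this position.

Cyclohexylmethyl in place of benzyl would help separate the part played by the aromatic ring from that of the group's size, and phenyl joined directly to the nitrogen would test the carbon link that benzyl places between the ring and the nitrogen. As far as these compounds go, it also remains open how much isopropyl contributes, since compound 3 and compound 4 both keep it, and a methyl or ethyl group in its place would address that.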